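Swapping 3-nitrophenyl for 3,4-dichlorophenyl

A few compounds are considered here, and "the series" means these few. Any claim that something is new, unique, unknown or untested is made for them only; others in the source may bear on it.

Compound 1 `O=C(N/N=C/c1ccccc1)Nc1ccc(Oc2ccnc3[nH]ccc23)c(F)c1`: 7940 nM
Compound 2 `O=C(N/N=C/c1cccc([N+](=O)[O-])c1)Nc1ccc(Oc2ccnc3[nH]ccc23)c(F)c1`: 5140 nM

Both values come from a functional assay on PC-3 cells (Homo sapiens) for antiproliferative activity, read by MTT assay, with a stated time of 72 h; on this read-out higher numbers stand for weaker inhibition and lower numbers for stronger inhibition. Going by the values given here, compound 2, at 5140 nM, cannot be separated from compound 1, its only measured neighbour. Compound 3 `O=C(N/N=C/c1ccc(Cl)c(Cl)c1)Nc1ccc(Oc2ccnc3[nH]ccc23)c(F)c1` has 3,4-dichlorophenyl in place of 3-nitrophenyl on a carbon with a double bond to nitrogen. Among the compounds with values here, one measured step bears on this, since it also altered that phenyl group: a 1.5-fold lower number from compound 1 to compound 2 (0.19 log units; within the scatter). That step was small, so no change beyond the scatter is expected in this assay, though a single step is thin evidence. The expected change is a 1.1-fold lower number from compound 2 to compound 3 (0.06 log units; within the scatter). Compound 3 is estimated at 4500 nM, with an expected range from 1800 nM to 11000 nM.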

Compound 3, half-maximal inhibitory concentration: 14100 nM
Compound 3: the middle estimate sits 3.1-fold (0.50 log units) below what was measured; the whole stated range lies below it.
By their numbers in this assay, from the lowest: compounds 2, 1 and 3 (each within the scatter of the next, the first and the last beyond it).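

In this assay, going by these compounds alone, this position shows its first clear response: 3,4-dichlorophenyl in place of 3-nitrophenyl gives a 2.7-fold higher number from compound 2 to compound 3 (0.44 log units; beyond the scatter) and this is the only step here beyond the scatter. Against plain phenyl the same group gives a 1.8-fold higher number from compound 1 to compound 3 (0.25 log units; within the scatter) so only the gap to compound 2 can be read as a real change. Nothing available here explains that gap.

Still open, on these data alone, is how an amine or a carboxylic acid on this phenyl ring would compare, and whether a single chlorine would match the pair.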